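Ring-nitrogen methylation of compound 1: expected outcome

A few compounds are considered here, and "the series" means these few. Any claim that something is new, unique, unknown or untested is made for them only; others in the source may bear on it.

Compound 1 `N=C1NC(=O)/C(=C\c2c[nH]c3c(Br)cccc23)N1` is the reference point of this set. In an in vitro assay on HEK293 cells for displacement of a labelled ligand from 5-hydroxytryptamine receptor 1E (Homo sapiens) (on this read-out lower numbers stand for stronger inhibition and higher numbers for weaker inhibition), compound 1 gives > 10000 nM, which is a limit of the assay and not a number. The two other measured compounds end the same way. Compound 2 `C/N=C1\N(C)C(=O)/C(=C\c2c[nH]c3ccccc23)N1C` carries methyl groups on three nitrogens of the core and has no bromine; in this assay compound 2 gives > 10000 nM, again a limit. Compound 3 `CN1C(=N)NC(=O)/C1=C\c1c[nH]c2ccc(Br)cc12` carries a single methyl on a ring nitrogen together with a bromine; in this assay compound 3 gives > 10000 nM, also a limit. Compound 1 therefore stands at the same point as every neighbour: the limit of > 10000 nM in this assay, at which 3 of the 3 values shown sit. Going by the values given here, no step between measured compounds can be computed, as none differ in a single place.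

Compound 4 `CN1C(=N)NC(=O)/C1=C\c1c[nH]c2c(Br)cccc12` is not yet measured. It differs from compound 1 by methyl in place of hydrogen on an amine nitrogen in a ring. Compound 3, which already bears such a methyl, sits at the limit > 10000 nM. In this assay the step is expected to be a step that the limit leaves unreadable from compound 1 to compound 4, none beyond the scatter. Compound 4 is estimated at 20000 nM, within 8000 nM to 100000 nM, most likely reported as a limit once more.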

Compound 4, inhibition constant: > 10000 nM
Compound 4 was reported as a limit; the forecaster's own chance of this, stated with the estimate: 85%; the middle value lies beyond the limit too.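

No new step can be read between compound 1 and compound 4, as both are reported only as limits in this assay: the limit of > 10000 nM in this assay, at which 4 of the 4 values shown sit.

The compounds shown leave open whether methyl in place of hydrogen on an amine nitrogen in a ring changes the read-out at all, and what would bring any value of this series inside the limit.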